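From Acetamido to (Isopropylcarbonyl)amino in Compound 3

A few compounds are considered here, and "the series" means these few. Any claim that something is new, unique, unknown or untested is made for them only; others in the source may bear on it.

Within the data shown here, compound 2 `CC(=O)Nc1ncc(SCc2ncc(C(C)(C)C)o2)s1` gives 50 nM in a functional assay on A2780 cells (Homo sapiens) for cytotoxicity (a higher number here means a weaker inhibitor, a lower number a stronger inhibitor), the lowest of the two numbers measured so far; its nearest neighbour, compound 1 `CC(=O)Nc1ncc(SCc2ncc(C(C)C)o2)s1`, gives 200 nM, and the single measured step, a 4.0-fold lower number from compound 1 to compound 2 (0.60 log units; beyond the scatter), arises from methyl in place of hydrogen on a saturated chain carbon bound to an aromatic carbon and two saturated chain carbons. Compound 3 `CC(C)C(=O)Nc1ncc(SCc2ncc(C(C)(C)C)o2)s1` differs from compound 2 at a different place: isopropyl in place of methyl on a carbonyl carbon, that is acetyl to isopropylcarbonyl, or acetamido to (isopropylcarbonyl)amino. Among the measured compounds shown here, no measured step touches the carbonyl carbon, so the only step in hand does not bear on this change. Without such precedent, no step beyond the scatter is expected in either direction, and compound 3 is estimated at 50 nM in this assay, with a range from 15 nM to 160 nM. The step this implies, no change at the digits printed from compound 2 to compound 3 (within the scatter), is expected to lie within the usual scatter.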

Compound 3, half-maximal inhibitory concentration: 50 nM
Beside the measured number, compound 3's estimate shows no gap at the digits printed, within the range that was stated.
By their numbers in this assay, from the lowest: compounds 2 and 3 (each within the scatter of the next); then compound 1.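

In this assay, the carbonyl carbon receives its first measured change: isopropyl in place of methyl gives no change at the digits printed from compound 2 to compound 3 (within the scatter). Among these compounds, the one earlier step, a 4.0-fold lower number from compound 1 to compound 2 (0.60 log units; beyond the scatter), lay at a different place and beyond the scatter, whereas here a group of 3 heavy atoms stands in for a group of 1 with no step beyond the scatter, so this position accepts this exchange on the core of compound 2 in this assay. No accompanying evidence bears on why the number holds.

As far as these compounds go, it remains open whether a longer chain, a cyclopropyl ring or an amine on the same carbonyl carbon would leave the number equally in place. From the compounds shown here alone, it is also open whether isopropyl in place of methyl at this position would give the same result on the core of compound 1.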